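Chloro added to the phenyl of compound 2

This account rests on a few compounds, and the source may have more. Where it says the series, first, only, none or still open, it means among the compounds named here.

Working notes on two measured compounds and one to come. Compound 1 `O=C1CSC(N2N=C(c3ccc(Cl)c(Cl)c3)CC2c2ccccc2)=N1` in an ADME assay on RAW264.7 cells (Mus musculus) for cytotoxicity, read by MTT assay, with a stated time of 24 h (a higher number here means that more compound is tolerated, a lower number that less compound is tolerated), gives 295000 nM. Compound 2 `Cc1ccc(C2=NN(C3=NC(=O)CS3)C(c3ccccc3)C2)cc1C` in this assay gives only a limit of the assay, > 450000 nM, so its value is not a number. Among the compounds with values here, the only measured step, an at least 1.5-fold higher number from compound 1 to compound 2 (0.18 log units; that floor lies within the scatter), is a floor lying within the scatter, and the evidence for it is the limit of > 450000 nM in this assay, at which 1 of the 2 values shown sits. Compound 2 therefore stands at the tolerated end of the series, with no number fixed.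

Compound 3 `Cc1ccc(C2=NN(C3=NC(=O)CS3)C(c3ccccc3Cl)C2)cc1C` differs from compound 2 by chloro in place of hydrogen on an aromatic carbon. Within the data shown here, no measured step concerns this phenyl; the single step from compound 1 to compound 2 concerns the other aromatic ring, so it does not bear on the change. In this assay the expectation for compound 3 is for no step beyond the scatter, with a fair chance that again only a limit is returned. The step from compound 2 to compound 3 is expected as a number no higher from compound 2 to compound 3 (the limit leaves the size open). For compound 3 the estimate is 450000 nM, between 200000 nM and 1000000 nM.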

Compound 3, half-maximal cytotoxic concentration: 227000 nM
Compound 3: middle estimate off by 2.0-fold (0.30 log units), on the high side; low and high end bracket the measured number.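

In this assay, compound 3 returns a number where compound 2 returned only a limit, so the phenyl now has its first measured change, with chloro in place of hydrogen ortho to a large group: an at least 1.9-fold lower number from compound 2 to compound 3 (0.29 log units; that floor lies within the scatter) is the step. Within the data shown here, with its floor inside the scatter, this step does not establish a real loss of tolerance, but it is the first reading of any kind on this ring, as the earlier step concerned the other aromatic ring. Compound 2 holds a limit and not a number, so the true size of the step stays open, and the reading rests on this: the limit of > 450000 nM in this assay, at which 1 of the 3 values shown sits.

The compounds shown leave open whether chloro at another place on this phenyl, or a different group at this place, such as methoxy, an amine or a carboxylic acid, would give a step beyond the scatter in this assay. They also leave open whether the same change would read alike with 3,4-dichlorophenyl in place of 3,4-dimethylphenyl on the other ring; only compound 3 carries this chloro.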